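Amino for Ethyl on the Imine Nitrogen

A few compounds are considered here, and "the series" means these few. Any claim that something is new, unique, unknown or untested is made for them only; others in the source may bear on it.

Compound 2 `CC/N=C(\S)[C@]1(c2cccnc2)CCCC[S+]1[O-]` holds the lower of the two numbers measured in a functional assay (aorta) for inhibition, with Rattus norvegicus as the target (a higher number here means a weaker inhibitor, a lower number a stronger inhibitor), where compound 2 gives 300 nM. Compound 1 `C/N=C(\S)[C@]1(c2ccns2)CCCC[S+]1[O-]` gives 7000 nM in this assay, a gap beyond the usual scatter. Compound 3 `N/N=C(\S)[C@]1(c2cccnc2)CCCC[S+]1[O-]` differs from compound 2 by amino in place of ethyl on a double-bonded nitrogen. Among the measured compounds shown here, no measured pair shows this change, so its effect has no direct precedent here. A modest weakening beyond the scatter is expected from compound 2 to compound 3, as the step of a 2.3-fold higher number from compound 2 to compound 3 (0.37 log units; beyond the scatter). Compound 3 is accordingly estimated at 700 nM, within a range from 150 nM to 3500 nM.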

Compound 3, concentration for 90% inhibition: > 30000 nM
Compound 3: only a limit was reported; the forecaster's own chance of this, stated with the estimate: 5%; at least 42-fold (1.63 log units) between middle value and limit.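

Amino in place of ethyl on a double-bonded nitrogen brings an at least 100-fold higher number from compound 2 to compound 3 (2.00 log units; beyond the scatter) in this assay. Among the compounds shown here, this single change at this place thus costs far more than the earlier compounds could reveal, since no measured pair had tested it. Compound 3 carries a limit rather than a number, so the full size of the step stays unknown: the limit of > 30000 nM in this assay, at which 1 of the 3 values shown sits.

From the compounds shown here alone, what stays open is whether other groups on this nitrogen, such as a propyl chain, a hydroxyl or a methylamino group, would hold the level of compound 2. The compounds shown also leave open whether ethyl itself matters or amino alone causes the loss.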